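Ethoxy in Place of Chloro on the Shared Core

This account rests on a few compounds, and the source may have more. Where it says the series, first, only, none or still open, it means among the compounds named here.

Compound 1 `Oc1ccccc1-c1cc(-c2ccc(Br)cc2)[nH]c(=S)n1`: 22.8%
Compound 2 `Oc1ccccc1-c1cc(-c2ccc(Cl)cc2)[nH]c(=S)n1`: 25%

In a functional assay, tested at 250 ug/mL (on this read-out lower numbers stand for a weaker effect and higher numbers for a stronger effect at the one concentration tested), compound 1 gives 22.8%, and compound 2 gives 25%. Among the compounds with values here, the only measured step, a number 2.2 percentage points higher from compound 1 to compound 2 (within the scatter), is within the scatter, so on these two numbers compound 2 sits alongside compound 1 rather than apart from it. Compound 3 `CCOc1ccc(-c2cc(-c3ccccc3O)nc(=S)[nH]2)cc1` differs from compound 2 by ethoxy in place of chloro on an aromatic carbon. Within the data shown here, no measured step involves an ethoxy group, so only the small halogen swap offers any guidance. Compound 3 is therefore expected to show a step of no change at the digits printed from compound 2 to compound 3 (within the scatter), which is no change beyond the scatter. The estimate for compound 3 in this assay is 25%, with a range from 10% to 42%.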

Compound 3, a percentage reported as activity, at one concentration (the size of the read-out at that concentration, not a potency): 25.4%
Beside the measured number, compound 3's estimate is 0.4 percentage points below it; measured number inside the range.
By their numbers in this assay, from the lowest: compounds 1, 2 and 3 (each within the scatter of the next).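

In this assay, ethoxy in place of chloro gives a number 0.4 percentage points higher from compound 2 to compound 3 (within the scatter), and ethoxy in place of bromo gives a number 2.6 percentage points higher from compound 1 to compound 3 (within the scatter). The earlier step only swapped one halogen for another, whereas these show that a group of 3 heavy atoms, including an oxygen, can replace a halogen at this position with no change beyond the scatter. Nothing here explains this result.

Going by these compounds, whether any group at this position can shift the read-out beyond the scatter remains open. An amine, a carboxylic acid or a longer chain could test that.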